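The compounds below may be only part of what the source reports. "The series", "measured", "known", "first", "only" and "open" are said of these compounds alone.

Of the compounds shown here, two with a shared core have been measured so far in a functional assay on MGC-803 cells (Homo sapiens) for cytotoxicity, read by MTT assay, with a stated time of 48 h; a lower number here means a stronger inhibitor, a higher number a weaker inhibitor. Compound 1, `CC1=NN(C(=O)CN2CCCCC2)C(c2ccccc2O)C1`, gives 4310 nM. Compound 2, `COc1ccccc1C1CC(C)=NN1C(=O)CN1CCC(OC)CC1`, gives 9550 nM, the higher of the two numbers, which makes it the weaker inhibitor of the pair, and the gap between them lies beyond the scatter. These two compounds differ in more than one place, so their gap cannot be tied to any single change.

Compound 3, `COc1ccccc1C1CC(C)=NN1C(=O)C[N+]1(C)CCCC1`, has not yet been measured. It keeps the rest of compound 2 and changes one group, on a saturated chain carbon bound to a carbonyl carbon: a group of 6 heavy atoms (5 carbon, 1 nitrogen; one five-membered non-aromatic ring with 1 hetero atom) in place of a group of 8 heavy atoms (6 carbon, 1 nitrogen, 1 oxygen; one six-membered non-aromatic ring with 1 hetero atom), on a saturated chain carbon bound to a carbonyl carbon. The 4-methoxypiperidin-1-yl group that leaves has no net charge, while the group that enters has a net charge of +1. Among the compounds with values here, no measured pair shows what a swap of this kind does in this assay, so any expectation here is loose. The estimated change is a 1.4-fold lower number from compound 2 to compound 3 (0.13 log units; within the scatter), a small step expected to stay within the scatter. Compound 3 is expected at 7000 nM, with an estimated range from 2000 nM to 25000 nM.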

Compound 3, half-maximal inhibitory concentration: 12200 nM
Estimate against measurement, compound 3: 1.7-fold (0.24 log units) below, within the range that was stated.
By their numbers in this assay, from the lowest: compound 1; then compounds 2 and 3 (each within the scatter of the next).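

In this assay, within the data shown here, this is the first step that can be read at one place, the saturated chain carbon bound to a carbonyl carbon: swapping the 4-methoxypiperidin-1-yl group for the charged five-membered ring gives a 1.3-fold higher number from compound 2 to compound 3 (0.11 log units; within the scatter). So compound 2 and compound 3 cannot be told apart here, even though the swap alters the ring size, removes the hydrogen-bond acceptors counted on the leaving group and brings in a net charge of +1, which means that this assay does not register this particular combination of changes at this place. Nothing measured independently of this assay bears on why the two compounds read alike.

Because ring size, acceptor count and charge all change in one step, the result cannot separate them, and an uncharged pyrrolidin-1-yl group at the same place would be the direct way to pull charge apart from ring size. As far as these compounds go, it also remains open whether a group of a different kind there, such as a carboxylic acid, a primary amine or a longer chain ahead of the ring, would move the number beyond the scatter.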